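Amino substitution on the shared core: two benzyl isomers

The compounds below may be only part of what the source reports. "The series", "measured", "known", "first", "only" and "open" are said of these compounds alone.

Compound 1 `ClCc1ccc(Cn2cnc3c(Cl)ncnc32)cc1` is the reference point of the set. In a functional assay on 786-0 cells (Homo sapiens) for cytotoxicity, read by sulforhodamine B assay, with a stated time of 48 h (on this read-out lower numbers stand for higher toxicity in this test and higher numbers for lower toxicity in this test), compound 1 gives 21400 nM. Compound 2 `Nc1nc(Cl)c2ncn(Cc3ccc(CCl)cc3)c2n1` carries the change amino in place of hydrogen on an aromatic carbon relative to compound 1. In this assay compound 2 reaches only a limit, > 100000 nM, so the value is a limit and not a number. The step of an at least 4.6-fold higher number from compound 1 to compound 2 (0.66 log units; beyond the scatter) therefore rests on the limit of > 100000 nM in this assay, at which 1 of the 3 values shown sits, and is a lower bound. Compound 3 `ClCc1ccccc1Cn1cnc2c(Cl)ncnc21` has the same atoms as compound 1 joined differently; the difference between the two cores is not broken down here. In this assay compound 3 gives 83200 nM, the highest of the two numbers measured, with its gap to compound 1 beyond the scatter. Compound 4 `Nc1nc(Cl)c2ncn(Cc3ccccc3CCl)c2n1` is not yet measured; it differs from compound 3 by amino in place of hydrogen on an aromatic carbon, the same change as from compound 1 to compound 2 at the same place. Compound 4 is expected to sit at or past the limit because the earlier step of an at least 4.6-fold higher number from compound 1 to compound 2 (0.66 log units; beyond the scatter) already ran to one from a lower starting number. The expected step is a 3.6-fold higher number from compound 3 to compound 4 (0.56 log units; beyond the scatter). The estimate for compound 4 is 300000 nM, with a range from 80000 nM to 1500000 nM.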

Compound 4, concentration lethal to 50% of the cells: > 100000 nM
Compound 4 ended at the assay's limit; the forecaster's own chance of this, stated with the estimate: 85%; the middle value does not contradict the limit.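

In this assay, placing amino on the core of compound 3 gives an at least 1.2-fold higher number from compound 3 to compound 4 (0.07 log units; that floor lies within the scatter), and this step rests on a limit of the assay and not on a number. The change carries over in one plain sense, as the amino compound on each core ends at the limit and neither gives a number, but this does not establish that the step has the same size on both cores: the same change on two cores in this assay, an at least 4.6-fold higher number (0.66 log units; beyond the scatter) from compound 1 to compound 2 and an at least 1.2-fold higher number (0.07 log units; that floor lies within the scatter) from compound 3 to compound 4; the limit leaves it open whether they differ The two amino compounds therefore cannot be ranked against each other or against any higher reading, and the comparison stops at the assay's ceiling: the limit of > 100000 nM in this assay, at which 2 of the 4 values shown sit.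

The compounds shown leave open whether another group at the same place, such as a dimethylamino group or a hydroxy group, would give a number inside the range of the assay on either core. They also leave open how a longer chain or a carboxylic acid in place of the chloromethyl group would read in this assay.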